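The source may hold more compounds than are shown below. What is called first, only, known or untested is meant among the compounds shown, and "the series" means these compounds.

Working notes on the series. In a functional assay on MCF7 cells (Homo sapiens) for inhibition, read by MTT assay, with a stated time of 5 days (on this read-out higher numbers stand for weaker inhibition and lower numbers for stronger inhibition), compound 1 (`Cc1cc(Nc2nc(NCc3ccccc3Cl)nc3[nH]ncc23)n[nH]1`) gives 4130 nM and compound 2 (`Cc1cc(Nc2nc(NCc3cccc(Cl)c3)nc3[nH]ncc23)n[nH]1`) gives 5620 nM while compound 3 (`Cc1cc(Nc2nc(NCc3ccc(Br)cc3)nc3[nH]ncc23)n[nH]1`) gives 5340 nM on the same read-out. Compound 2 has no separate rank among these three, as the steps show (a 1.4-fold higher number from compound 1 to compound 2 (0.13 log units; within the scatter); a 1.1-fold lower number from compound 2 to compound 3 (0.02 log units; within the scatter); a 1.3-fold higher number from compound 1 to compound 3 (0.11 log units; within the scatter)).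

The change under study leads to compound 4 (`Cc1cc(Nc2nc(NCc3ccc(C#N)cc3)nc3[nH]ncc23)n[nH]1`) and puts 4-cyanophenyl in place of 3-chlorophenyl on a saturated chain carbon bound to a nitrogen on an aromatic ring. For the measured compounds named here, no compound with a nitrile has been measured, so the three steps above bear on it only indirectly, as swaps of the aryl group at this same place. The closest of them is the change to 4-bromophenyl (a 1.1-fold lower number from compound 2 to compound 3 (0.02 log units; within the scatter)). No step beyond the scatter is therefore expected in this assay, and no direction is favoured. The expected step is small (a 1.1-fold lower number from compound 2 to compound 4 (0.05 log units; within the scatter)). For compound 4 the estimated value is 5000 nM with an expected range (2300 nM to 11000 nM).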

Compound 4, half-maximal inhibitory concentration: 6060 nM
Estimate against measurement, compound 4: 1.2-fold (0.08 log units) below; the measured number falls inside the stated range.
By their numbers in this assay, from the lowest: compounds 1, 3, 2 and 4 (each within the scatter of the next).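

In this assay, swapping in the nitrile at this place leaves the number flat against all three halogenated compounds: a 1.1-fold higher number from compound 2 to compound 4 (0.03 log units; within the scatter), a 1.1-fold higher number from compound 3 to compound 4 (0.05 log units; within the scatter) and a 1.5-fold higher number from compound 1 to compound 4 (0.17 log units; within the scatter). The place on a saturated chain carbon bound to a nitrogen on an aromatic ring thus accepts 4-cyanophenyl, with its triple bond and a hydrogen-bond acceptor that 3-chlorophenyl lacks, without a step beyond the scatter. Nothing available bears on why these four compounds read alike.

Still open, on these data alone, is whether any change at this place can move the number beyond the scatter, in either direction, since all four compounds carry a substituted phenyl here. As far as these compounds go, what a carboxylic acid or an amine on that phenyl, or a longer chain in front of it, would do remains unknown.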